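A few compounds are considered here, and "the series" means these few. Any claim that something is new, unique, unknown or untested is made for them only; others in the source may bear on it.

Measured in a functional assay on SK-MEL-5 cells (Homo sapiens) for cytotoxicity, read by sulforhodamine B assay, with a stated time of 48 h; on this read-out higher numbers stand for lower toxicity in this test and lower numbers for higher toxicity in this test: compound 1 `ClCc1ccc(Cn2cnc3c(Cl)ncnc32)cc1` gives 74100 nM; compound 2 `ClCc1cccc(Cn2cnc3ncnc(Cl)c32)c1` gives 45700 nM; compound 3 `ClCc1ccc(Cn2cnc3nc(Cl)nc(Cl)c32)cc1` gives 31600 nM.

Compound 2 holds the second-highest of these three numbers. Its nearest neighbour is compound 3 and its furthest is compound 1, and both of those gaps fall within the usual scatter of this assay, so no order among them can be read from compound 2's number alone. Compound 4 `ClCc1cccc(Cn2cnc3nc(Cl)nc(Cl)c32)c1` differs from compound 2 by chloro in place of hydrogen on an aromatic carbon. Within the data shown here, no directly comparable step has been measured. The pair of compound 1 and compound 3 shows a lower number for the compound carrying the second chloro group, and a change in the same direction, of modest size, is expected in this assay for compound 4. The step from compound 2 to compound 4 is estimated as a 1.8-fold lower number from compound 2 to compound 4 (0.26 log units; within the scatter). Compound 4 is expected to give about 25000 nM, with a range from 10000 nM to 60000 nM.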

Compound 4, concentration lethal to 50% of the cells: 4890 nM
Compound 4: middle estimate off by 5.1-fold (0.71 log units), on the high side, outside the stated range (below it).
By their numbers in this assay, from the lowest: compound 4; then compounds 3, 2 and 1 (each within the scatter of the next, the first and the last beyond it).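

In this assay, chloro in place of hydrogen on the aromatic carbon between two ring nitrogen atoms gives a 9.3-fold lower number from compound 2 to compound 4 (0.97 log units; beyond the scatter). Among these compounds, this is the first comparison of compounds differing in one place, and it shows that toxicity in this test responds clearly to a single added chlorine at this position. Nothing available explains the size of this step. On these data alone, whether an amine, a methoxy group or fluoro on the same carbon would also lower the number remains open. As far as these compounds go, it is also open whether chloro has the same effect in a compound built like compound 1.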